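Cutting a Benzyl Ether Down to a Methyl Ether

The source may hold more compounds than are shown below. What is called first, only, known or untested is meant among the compounds shown, and "the series" means these compounds.

Measured in a functional assay on DU-145 cells (Homo sapiens) for inhibition, read by trypan blue exclusion, with a stated time of 96 h; on this read-out higher numbers stand for weaker inhibition of growth and lower numbers for stronger inhibition of growth:
Compound 1 `O=C(/C(=C\c1ccccc1OCc1ccccc1)SCc1ccc(Cl)c(Cl)c1)c1ccc(Cl)cc1` gives 10000 nM.
Compound 2 `O=C(/C(=C\c1ccccc1OCc1ccccc1)SCc1ccc(F)cc1)c1ccc(Cl)cc1` gives 1000 nM.
Compound 3 `O=C(O)c1ccc(C(=O)/C(=C\c2ccc(Br)cc2)SCc2ccc(Br)cc2)cc1` gives 1000 nM.

Compound 2 stands level with compound 3 at the digits shown, the two together giving the lowest numbers of the three, while compound 1 lies a step away: a 10-fold lower number from compound 1 to compound 2 (1.00 log units; beyond the scatter). Compound 4 `COc1ccccc1/C=C(/SCc1ccc(F)cc1)C(=O)c1ccc(Cl)cc1` differs from compound 2 in one place: hydrogen in place of phenyl on a saturated chain carbon bound to an oxygen on an aromatic ring. For the measured compounds named here, the only measured step sits elsewhere, on the saturated chain carbon bound to a sulfur, so no measured step bears on this change. With nothing pointing either way, no step beyond the scatter is expected in this assay, meaning no change at the digits printed from compound 2 to compound 4 (within the scatter). Compound 4 is therefore estimated at 1000 nM, with a range from 300 nM to 3500 nM.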

Compound 4, concentration for 50% growth inhibition: 10000 nM
The estimate for compound 4 lay 10-fold (1.00 log units) below the measured number; the whole stated range lies below it.
By their numbers in this assay, from the lowest: compounds 2 and 3 (each within the scatter of the next); then compounds 1 and 4 (each within the scatter of the next).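

Going from benzyloxy to methoxy gives a 10-fold higher number from compound 2 to compound 4 (1.00 log units; beyond the scatter) in this assay, the first measured change at this place, on a saturated chain carbon bound to an oxygen on an aromatic ring. The phenyl therefore cannot be removed here without a loss in growth inhibition, at least with the 4-fluorophenyl group kept in place. Nothing measured here explains this step. Still open, on these data alone, is how an ethyl group, a longer chain or a chain ending in an amine would read at this oxygen. As far as these compounds go, whether the same change would matter with the 3,4-dichlorophenyl group in place also remains open.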